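Nitro to ethyl on the aryl ring of the shared core

The compounds below may be only part of what the source reports. "The series", "measured", "known", "first", "only" and "open" are said of these compounds alone.

Measured so far:
- compound 1 `CN(C)c1ccc(N2C(=O)NC3(CSC4=C3C(=O)c3ncccc3C4=O)C2=O)cc1`: 20 nM
- compound 2 `CCCc1ccc(N2C(=O)NC3(CSC4=C3C(=O)c3ncccc3C4=O)C2=O)cc1`: 1 nM
- compound 3 `O=C1C2=C(C(=O)c3ncccc31)C1(CS2)NC(=O)N(c2ccc([N+](=O)[O-])cc2)C1=O`: 250 nM

In a functional assay on HT-29 cells (Homo sapiens) for antiproliferative activity, read by MTT assay, with a stated time of 96 h (on this read-out higher numbers stand for weaker inhibition and lower numbers for stronger inhibition), compound 3 gives 250 nM, the highest number of the three; its nearest neighbour is compound 1 with 20 nM, its furthest is compound 2 with 1 nM. The step of a 13-fold higher number from compound 1 to compound 3 (1.10 log units; beyond the scatter) and the step of a 250-fold higher number from compound 2 to compound 3 (2.40 log units; beyond the scatter) both place compound 3 clearly apart from the others.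

Compound 4 `CCc1ccc(N2C(=O)NC3(CSC4=C3C(=O)c3ncccc3C4=O)C2=O)cc1` is not yet measured. It differs from compound 3 by ethyl in place of nitro on an aromatic carbon.

The step that bears most directly on this change is a 250-fold higher number from compound 2 to compound 3 (2.40 log units; beyond the scatter), since propyl and ethyl differ only in chain length and both are plain carbon chains carrying no acceptors. The step of a 13-fold higher number from compound 1 to compound 3 (1.10 log units; beyond the scatter) points the same way: removing the nitro group has given a much lower number whichever group stood in its place. Reversing the direction, a large drop in this assay is therefore expected on going from compound 3 to compound 4, of roughly the size seen between compound 2 and compound 3, with some allowance for ethyl being one carbon shorter than propyl.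

For compound 4 the expected value in this assay is 2.5 nM, with a range of 0.8 nM to 10 nM, which corresponds to an expected step of a 100-fold lower number from compound 3 to compound 4 (2.00 log units; beyond the scatter).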

Compound 4, half-maximal inhibitory concentration: 1 nM
The estimate for compound 4 lay 2.5-fold (0.40 log units) above the measured number, and the stated range covers the measured number.
By their numbers in this assay, from the lowest: compounds 2 and 4 (each within the scatter of the next); then compound 1; then compound 3.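

Ethyl in place of nitro on the aromatic carbon gives a 250-fold lower number from compound 3 to compound 4 (2.40 log units; beyond the scatter) in this assay and so shows that the large distance from the nitro compound is not confined to propyl. Going from propyl to ethyl gives no change at the digits printed from compound 2 to compound 4 (within the scatter) and so, for these two chains, the length of the chain does not separate the compounds on this read-out. With a 20-fold lower number from compound 1 to compound 4 (1.30 log units; beyond the scatter) as well, ethyl stands apart from dimethylamino just as propyl does, which places both plain carbon chains on the same side of dimethylamino and nitro in this assay while no measurement at hand offers a reason for this order.

On these data alone, whether the level shared by ethyl and propyl continues to a butyl chain or a branched chain such as isopropyl remains open. As far as these compounds go, whether it also holds for a methyl group or plain hydrogen remains open as well. Also open, from the compounds shown here alone, is where a methoxy group, a chlorine atom, a primary amine or a carboxylic acid would fall at this position relative to the carbon chains and to nitro.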